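Sulfonyl for carbonyl on the ring nitrogen of compound 1

A few compounds are considered here, and "the series" means these few. Any claim that something is new, unique, unknown or untested is made for them only; others in the source may bear on it.

Compound 1 `CN(C(=O)c1ccc(F)cc1)c1ccc2[nH]c(-c3n[nH]c4ccccc34)cc2n1` gives 7220 nM in a functional assay on KB cells (Homo sapiens) for antiproliferative activity, read by MTT assay, with a stated time of 72 h (on this read-out higher numbers stand for weaker inhibition and lower numbers for stronger inhibition), the second highest of three numbers. Compound 3 `CN(C(=O)c1ccccc1)c1ccc2[nH]c(-c3n[nH]c4cc(Cl)ccc34)cc2n1` gives 5590 nM and compound 2 `CN(C(=O)c1ccc([N+](=O)[O-])cc1)c1ccc2[nH]c(-c3n[nH]c4ccccc34)cc2n1` gives 20200 nM. Within the data shown here, the only single-point step among the measured compounds, a 2.8-fold higher number from compound 1 to compound 2 (0.45 log units; beyond the scatter), exchanges a substituent on the aryl ring rather than the linking group. Compound 4 `Cc1ccc(S(=O)(=O)N(C)c2ccc3[nH]c(-c4n[nH]c5ccccc45)cc3n2)cc1` differs from compound 1 by (4-methylphenyl)sulfonyl in place of (4-fluorophenyl)carbonyl on a nitrogen on an aromatic ring. Among the measured compounds shown here, no measured step touches the group on this nitrogen, and compound 3 differs from compound 1 in two places, so the measured steps give no direct guide. For compound 4 the expected step is therefore small, with no change beyond the scatter, a 1.1-fold higher number from compound 1 to compound 4 (0.04 log units; within the scatter). Compound 4 is estimated at 8000 nM, within 2500 nM to 25000 nM.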

Compound 4, half-maximal inhibitory concentration: 9500 nM
Compound 4: middle estimate off by 1.2-fold (0.07 log units), on the low side; low and high end bracket the measured number.
By their numbers in this assay, from the lowest: compounds 3, 1 and 4 (each within the scatter of the next); then compound 2.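

Among these compounds, on the nitrogen on an aromatic ring, (4-methylphenyl)sulfonyl can take the place of (4-fluorophenyl)carbonyl in this assay with no change beyond the scatter, a 1.3-fold higher number from compound 1 to compound 4 (0.12 log units; within the scatter); this is the first reading of any change to this group. The linking group and the aryl substituent change together in this step, so it does not give the contribution of either alone. No supporting data bear on why the number holds across this change.

Still open, as far as these compounds go, is whether a (4-fluorophenyl)sulfonyl group would read like compound 4. Also open, from the compounds shown here alone, is how an amine or a carboxylic acid on the aryl ring, or a longer chain on this nitrogen, would read.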